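Replacing the Triazole Arm of Compound 1 with a Methyl Ester

The source may hold more compounds than are shown below. What is called first, only, known or untested is meant among the compounds shown, and "the series" means these compounds.

Compound 1 `N#Cc1c(N)nc(SCn2cncn2)c(C#N)c1-c1ccc(OCC2CC2)cc1`: 1%
Compound 2 `N#Cc1c(N)nc(SCc2csc(N)n2)c(C#N)c1-c1ccc(OCC2CC2)cc1`: 1%
Compound 3 `C=CCOc1ccc(-c2c(C#N)c(N)nc(SCc3ccn[nH]3)c2C#N)cc1`: 13%

In an assay on CHO cells for displacement of a labelled ligand from adenosine receptor A3 (Homo sapiens), read by scintillation counting, with a stated time of 120 min, tested at 1 uM (a lower number here means less inhibition, a higher number more inhibition at the concentration tested (going by the name of the read-out)), compound 1 gives 1%, level with compound 2 and, together with it, the lowest of the three numbers; only compound 3 stands beyond the scatter above it. Compound 4 `COC(=O)CSc1nc(N)c(C#N)c(-c2ccc(OCC3CC3)cc2)c1C#N` arises from compound 1 by methoxycarbonyl in place of 1H-1,2,4-triazol-1-yl on a saturated chain carbon bound to a sulfur. Among the compounds with values here, the one measured step at this same position, no change at the digits printed from compound 1 to compound 2 (within the scatter), shows that exchanging one five-membered aromatic ring for another there left the inhibition unchanged. Since compound 1 already sits at the floor of the read-out, the expected step of a number 2 percentage points higher from compound 1 to compound 4 (within the scatter) is none beyond the scatter. Compound 4 is therefore estimated at 3%, within 0% to 12%.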

Compound 4, a percentage reported as inhibition, at one concentration (the size of the read-out at that concentration, not a potency): 1%
Compound 4: the middle estimate sits 2 percentage points above what was measured; the range from low to high includes it.
By their numbers in this assay, from the lowest: compounds 1, 2 and 4 (each within the scatter of the next); then compound 3.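

The ring need not be kept at this place: in this assay, the open methoxycarbonyl gives no change at the digits printed from compound 1 to compound 4 (within the scatter), and against the aminothiazole arm it gives no change at the digits printed from compound 2 to compound 4 (within the scatter), whereas the earlier step had only exchanged one five-membered aromatic ring for another. On a saturated chain carbon bound to a sulfur, the triazole, the aminothiazole and the methyl ester thus read alike at this concentration. Nothing measured here accounts for this. Still open, going by these compounds, is whether a carboxylic acid, a primary amide or a longer chain in place of methoxycarbonyl would move the inhibition beyond the scatter.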